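The compounds below may be only part of what the source reports. "The series", "measured", "known", "first", "only" and "open" are said of these compounds alone.

Working notes on the series. In an assay on isolated protein (Oryctolagus cuniculus) with Thromboxane-A synthase (Homo sapiens) as the target, tested at 1 uM (a lower number here means less inhibition, a higher number more inhibition at the concentration tested (going by the name of the read-out)), compound 1 `O=c1c2ccccc2c(-c2cccnc2)nn1C1CCCC1` gives 97%. Compound 2 `O=c1c2ccccc2c(-c2cccnc2)nn1CC1CCCCC1` gives 98%, and compound 3 `O=c1c2ccccc2c(-c2cccnc2)nn1Cc1ccccc1` gives 97%. The step of a number 1 percentage points higher from compound 1 to compound 2 (within the scatter) goes with cyclohexylmethyl in place of cyclopentyl on an aromatic nitrogen, the step of no change at the digits printed from compound 1 to compound 3 (within the scatter) with benzyl in place of cyclopentyl on an aromatic nitrogen, and the step of a number 1 percentage points lower from compound 2 to compound 3 (within the scatter) with phenyl in place of cyclohexyl on a saturated chain carbon bound to an aromatic nitrogen. Compound 3 therefore stands level with compound 1 at the digits shown, and all three numbers lie within the scatter of one another; compound 2 is the one that differs from compound 3 at all, and only by a single point.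

Compound 4 `CCOC(=O)Cn1nc(-c2cccnc2)c2ccccc2c1=O` has not been measured. Its difference from compound 3 is ethoxycarbonyl in place of phenyl on a saturated chain carbon bound to an aromatic nitrogen. Of the measured steps only a number 1 percentage points lower from compound 2 to compound 3 (within the scatter) touches the same carbon, and it swapped one six-membered ring for another without moving the number beyond the scatter. Among the compounds with values here, no measured step removes the ring at that carbon or brings in a group with hydrogen-bond acceptors, so there is no direct precedent for the change to compound 4. As every measured change at that position has left the number level within the scatter, a small drop in the number is expected at most, with an estimated step of a number 7 percentage points lower from compound 3 to compound 4 (within the scatter). Compound 4 is estimated at 90%, in a range from 70% to 99%.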

Compound 4, a percentage reported as inhibition, at one concentration (the size of the read-out at that concentration, not a potency): 28%
For compound 4 the middle estimate is 62 percentage points above the measured one; the whole stated range lies above it.
By their numbers in this assay, from the lowest: compound 4; then compounds 1, 3 and 2 (each within the scatter of the next).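

The position on the aromatic nitrogen is not indifferent in this assay: the step of a number 69 percentage points lower from compound 3 to compound 4 (beyond the scatter), which goes with ethoxycarbonyl in place of phenyl on a saturated chain carbon bound to an aromatic nitrogen, is large, whereas cyclopentyl, cyclohexylmethyl and benzyl had all stayed within the scatter of one another. Within the data shown here, the fall does not depend on the reference chosen, since the step of a number 70 percentage points lower from compound 2 to compound 4 (beyond the scatter) and the step of a number 69 percentage points lower from compound 1 to compound 4 (beyond the scatter) are of the same large size, so the level shared by the three ring-bearing groups does not extend to (ethoxycarbonyl)methyl, the one group here with no ring and with hydrogen-bond acceptors. Nothing at hand explains this fall in the number.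

Ring loss and arrival of the ester come together in compound 4, so the compounds shown cannot say which of the two goes with the fall; a plain ethyl or a longer saturated carbon chain on the same nitrogen would bear on that. Also open, on these data alone, is how the number responds to a carboxylic acid or a primary amide in place of ethoxycarbonyl on that saturated chain carbon.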